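Inverting the chain stereocentre of compound 3

This account rests on a few compounds, and the source may have more. Where it says the series, first, only, none or still open, it means among the compounds named here.

Measured in a functional assay on the whole organism with Rattus norvegicus as the target; a higher number here means that more compound is needed for the effect, a lower number that less compound is needed:
- compound 1 `CC(C#CC[N+](C)(C)C)OC(=O)Nc1cccc(Cl)c1`: 0.09 umol/kg
- compound 2 `C[C@H](C#CC[N+](C)(C)C)OC(=O)Nc1cccc(Cl)c1`: 0.18 umol/kg
- compound 3 `C[C@H](C#CC[N+](C)(C)C)OC(=O)Nc1ccc(Cl)cc1`: 0.039 umol/kg

Compound 3, at 0.039 umol/kg, has the lowest number of the three, with compound 1 nearer to it and compound 2 further off. The next compound, compound 4 `C[C@@H](C#CC[N+](C)(C)C)OC(=O)Nc1ccc(Cl)cc1`, changes one thing only: the two compounds have the same atoms and bonds and differ only in configuration as drawn: 1 of 1 stereo elements differ; a stereocentre at a saturated chain carbon is drawn R in compound 3 and S in compound 4. A stereocentre at a saturated chain carbon is drawn R in compound 3 and S in compound 4.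

Among the compounds with values here, one measured step bears on this: a 2.0-fold higher number from compound 1 to compound 2 (0.30 log units; within the scatter). Within the data shown here, the only difference in that pair is the fact that one of compounds 1 and 2 is drawn with a defined configuration and the other without, at the place where they differ. Among the measured compounds shown here, its chlorine sits elsewhere than in compound 3, and it compares an R form with an undefined form, not R with S. It therefore offers only a faint hint that the S form needs no more compound in this assay. On that basis, the expected change is small and leans towards a lower number: a 1.6-fold lower number from compound 3 to compound 4 (0.19 log units; within the scatter). Compound 4 is estimated at 0.025 umol/kg, with an expected range of 0.005 umol/kg to 0.15 umol/kg.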

Compound 4, dose for half-maximal effect: 0.008 umol/kg
The estimate for compound 4 lay 3.1-fold (0.49 log units) above the measured number; the measured number falls inside the stated range.
By their numbers in this assay, from the lowest: compound 4; then compound 3; then compounds 1 and 2 (each within the scatter of the next).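

In this assay, the S form at the chain stereocentre needs less compound than the R form, with a 4.9-fold lower number from compound 3 to compound 4 (0.69 log units; beyond the scatter). The earlier step, a 2.0-fold higher number from compound 1 to compound 2 (0.30 log units; within the scatter), set an R form against an undefined form and stayed within the scatter, so it could not separate the two configurations. This pair gives the first direct comparison of R with S, and its gap can be assigned to the stereocentre alone: the fact that compounds 3 and 4 differ only in the configuration as drawn

From the compounds shown here alone, whether S also needs less compound than R with the chlorine placed as in compounds 1 and 2 remains open, as this comparison rests on a single pair. Also open, going by these compounds, is whether the gap would persist with a bromine in place of the chlorine, or with a tertiary amine in place of the trimethylammonium group.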